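Methylamino to benzylamino on compound 3

The compounds below may be only part of what the source reports. "The series", "measured", "known", "first", "only" and "open" are said of these compounds alone.

Among the compounds with values here, in a functional assay on L02 cells (Homo sapiens) for inhibition, read by Griess assay, with stated times of 1 h and 24 h (on this read-out higher numbers stand for weaker inhibition and lower numbers for stronger inhibition), compound 3 (`CNc1nc(/C=C/c2ccco2)nc2ccsc12`) gives 811000 nM and holds the highest of the two numbers so far. Compound 1 (`CCCc1nn(C)c2c(NC3CC3)nc(/C=C/c3cccnc3)nc12`) gives 261000 nM and is the nearest number, lower than that of compound 3 by more than the scatter. Compound 2 (`CNc1nc(/C=C/c2ccccc2)nc2ccsc12`) reads > 1000000 nM as a limit and not a number.

The next change gives compound 4 (`C(=C/c1ccco1)\c1nc(NCc2ccccc2)c2sccc2n1`) through phenyl in place of hydrogen on a saturated chain carbon bound to a nitrogen on an aromatic ring and reads as methylamino to benzylamino. Within the data shown here, the only measured step is an at least 1.2-fold lower number from compound 2 to compound 3 (0.09 log units; that floor lies within the scatter) for furan-2-yl in place of phenyl on a double-bonded chain carbon bound to a double-bonded chain carbon. Among the measured compounds shown here, that step is open-ended because of the limit of > 1000000 nM in this assay, at which 1 of the 3 values shown sits, and it lies at another place than the new change, so no measured step speaks directly to the size of this one.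

For the measured compounds named here, a small move to a lower number in this assay is expected, resting only on compound 1 at 261000 nM as the one number under that of compound 3. The expected change is a 1.8-fold lower number from compound 3 to compound 4 (0.26 log units; within the scatter) and is not expected to pass beyond the scatter. For compound 4 the estimate is 450000 nM with an expected range from 130000 nM to 1000000 nM at its ends.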

Compound 4, half-maximal inhibitory concentration: > 1000000 nM
Compound 4: only a limit was reported; the forecaster's own chance of this, stated with the estimate: 20%; middle value at least 2.2-fold (0.34 log units) away from the limit.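

In this assay, within the data shown here, methylamino to benzylamino gives an at least 1.2-fold higher number from compound 3 to compound 4 (0.09 log units; that floor lies within the scatter), the first reading at this place on the series, with phenyl entering on a saturated chain carbon bound to a nitrogen on an aromatic ring. Compound 4 reads > 1000000 nM, which is a limit of the assay and not a number. The change therefore gives no sign of a lower number at this place, while the open-ended step neither establishes a rise beyond the scatter nor rules one out, and its true size cannot be read because of this: the limit of > 1000000 nM in this assay, at which 2 of the 4 values shown sit.

Going by these compounds, whether an amine or a carboxylic acid in place of phenyl on that saturated chain carbon would bring the reading under the limit stays open. Compound 1 differs from compound 3 in more than one place, so its cyclopropylamino group gives no direct reading on this position, and the effect of the amino substituent with any other group on the shared core remains unresolved.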